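This account rests on a few compounds, and the source may have more. Where it says the series, first, only, none or still open, it means among the compounds named here.

Measured so far in an assay on isolated protein (Cavia porcellus) with Sigma non-opioid intracellular receptor 1 (Homo sapiens) as the target, read by radioligand binding; a higher number here means a weaker inhibitor, a lower number a stronger inhibitor: compound 1 `CN(C)CCCCOc1ccc2oc(-c3ccccc3)cc(=O)c2c1` gives 400 nM; compound 2 `CN(C)CCCCCCCCCOc1ccc2oc(-c3ccccc3)cc(=O)c2c1` gives 202 nM; compound 3 `O=c1cc(-c2ccccc2)oc2ccc(OCCCCCCN3CCC(O)CC3)cc12` gives 121 nM.

Compound 3 has the lowest number of the three, but only a 3.3-fold lower number from compound 1 to compound 3 (0.52 log units; beyond the scatter) is beyond the scatter, while a 1.7-fold lower number from compound 2 to compound 3 (0.22 log units; within the scatter) and a 2.0-fold lower number from compound 1 to compound 2 (0.30 log units; within the scatter) are within it. All three measured steps alter the chain and its amine end and leave the other end of the shared core untouched.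

Compound 4 `O=c1cc(C2CCCCC2)oc2ccc(OCCCCCCN3CCC(O)CC3)cc12` differs from compound 3 at that untouched end: cyclohexyl in place of phenyl on an aromatic carbon. For the measured compounds named here, no measured step bears on this change, so nothing sets its size or direction. The step of a 1.2-fold higher number from compound 3 to compound 4 (0.09 log units; within the scatter) is therefore expected to be small, with a wide range. Compound 4 is estimated at 150 nM, between 40 nM and 600 nM.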

Compound 4, half-maximal inhibitory concentration: 46 nM
Compound 4: the middle estimate sits 3.3-fold (0.51 log units) above what was measured; the measured number falls inside the stated range.
By their numbers in this assay, from the lowest: compound 4; then compounds 3, 2 and 1 (each within the scatter of the next, the first and the last beyond it).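

At the carbon next to the ring oxygen, cyclohexyl in place of phenyl gives a 2.6-fold lower number from compound 3 to compound 4 (0.42 log units; beyond the scatter) in this assay, the first reading from outside the chain and its amine end. With this chain and its 4-hydroxypiperidin-1-yl end, an aromatic ring at this place is therefore not required for binding. No evidence on hand accounts for the step.

On these data alone, whether the step carries over to the dimethylamino chains of compound 1 and compound 2 remains open. So does the outcome with cyclopentyl, tert-butyl or a pyridine ring at this carbon.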